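Oxime geometry in a pyrimidinyl-piperazine series

This account rests on a few compounds, and the source may have more. Where it says the series, first, only, none or still open, it means among the compounds named here.

Measured so far:
compound 1, `O/N=C(/CCN1CCN(c2ccccn2)CC1)c1ccccc1`, 74%
compound 2, `O/N=C(\CCN1CCN(c2ncccn2)CC1)c1ccccc1`, 49%

Both were read in a functional assay on HEK293 cells with D(4) dopamine receptor (Homo sapiens) as the target, read by FLIPR; on this read-out higher numbers stand for larger maximal responses and lower numbers for smaller maximal responses. Compound 2 stands lowest of the two numbers; its nearest neighbour is compound 1, whose value lies higher by a gap beyond the scatter. Compound 3, `O/N=C(/CCN1CCN(c2ncccn2)CC1)c1ccccc1`, is not yet measured. Relative to compound 2, (the two compounds have the same atoms and bonds and differ only in configuration as drawn: 1 of 1 stereo elements differ; a double bond is drawn E in compound 2 and Z in compound 3). Going by the values given here, no measured pair isolates this change, so its size is open; a moderate step in either direction, or none beyond the scatter, is possible. Compound 3 is expected to give 60% in this assay , in the range 40% to 80%, meaning an estimated step of a number 11 percentage points higher from compound 2 to compound 3 (beyond the scatter).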

Compound 3, largest response reached (reported as efficacy), in percent of the reference or control that the assay uses: 52%
Compound 3: middle estimate off by 8 percentage points, on the high side; low and high end bracket the measured number.
By their numbers in this assay, from the lowest: compounds 2 and 3 (each within the scatter of the next); then compound 1.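

In this assay, changing the oxime double bond from E to Z gives a number 3 percentage points higher from compound 2 to compound 3 (within the scatter), so configuration at this position has no visible effect in the pyrimidin-2-yl series, and this pair isolates that one change: the fact that compounds 2 and 3 differ only in the configuration as drawn With the drawn configuration held the same, pyrimidin-2-yl in place of pyridin-2-yl gives a number 22 percentage points lower from compound 1 to compound 3 (beyond the scatter), the first isolated effect of this ring change, and it exceeds the scatter.

Still open, as far as these compounds go, is whether the pyridin-2-yl compounds are equally insensitive to oxime configuration. Also open, from the compounds shown here alone, is how phenyl in place of pyrimidin-2-yl, or a longer chain, would read.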